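The source may hold more compounds than are shown below. What is called first, only, known or untested is meant among the compounds shown, and "the series" means these compounds.

Values in a functional assay on cells (Erythrocyte, Rattus norvegicus) for inhibition, read by hemolysis, with a stated time of 1 h (on this read-out higher numbers stand for weaker inhibition and lower numbers for stronger inhibition), for the three measured compounds:

Compound 1 `COc1cc(OC)c(OC)cc1/C=C/C(=O)c1ccc(C)cc1`: 2.24 ug/mL
Compound 2 `COc1cc(OC)c(OC)cc1/C=C/C(=O)c1ccc(O)cc1`: 2.29 ug/mL
Compound 3 `COc1cc(C(=O)/C=C/c2cc(OC)c(OC)cc2OC)ccc1O`: 2.16 ug/mL

All three share the same core and differ only on the aryl ketone ring. The step of a 1.0-fold higher number from compound 1 to compound 2 (0.01 log units; within the scatter) and the step of a 1.1-fold lower number from compound 2 to compound 3 (0.03 log units; within the scatter) both stay within the scatter, so compound 2 sits level with compound 1 and with compound 3 on these numbers; nothing separates the three.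

Compound 4 `COc1cc(OC)c(OC)cc1/C=C/C(=O)c1ccc([N+](=O)[O-])cc1` is the next member. Its change from compound 2 is nitro in place of hydroxy on an aromatic carbon.

Of the measured steps, a 1.0-fold higher number from compound 1 to compound 2 (0.01 log units; within the scatter) is the one that bears directly on this, since it swaps the group on the same aromatic carbon and produced no movement beyond the scatter. The step of a 1.1-fold lower number from compound 2 to compound 3 (0.03 log units; within the scatter) touches a different aromatic carbon and likewise gave nothing beyond the scatter. Two exchanges at this ring have left the read-out flat, so for compound 4 a step of a 1.0-fold higher number from compound 2 to compound 4 (0.00 log units; within the scatter) is expected, that is, no movement beyond the scatter in either direction.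

Compound 4 is therefore estimated at 2.3 ug/mL, with a range from 1.2 ug/mL to 4.6 ug/mL.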

Compound 4, half-maximal inhibitory concentration: 2.34 ug/mL
Compound 4: middle estimate off by 1.0-fold (0.01 log units), on the low side, within the range that was stated.
By their numbers in this assay, from the lowest: compounds 3, 1, 2 and 4 (each within the scatter of the next).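

In this assay, going by these compounds alone, this aromatic carbon, para to a large group, now tolerates a much bigger change than the earlier compounds tested: nitro, with 3 heavy atoms and 0 hydrogen-bond donors, replaces hydroxy, with 1 heavy atom and 1 hydrogen-bond donor, and the read-out stays level (a 1.0-fold higher number from compound 2 to compound 4 (0.01 log units; within the scatter)). The direct exchange of methyl for nitro at the same carbon also stays within the scatter (a 1.0-fold higher number from compound 1 to compound 4 (0.02 log units; within the scatter)), so methyl, hydroxy and nitro cannot be told apart here, and loss of the hydrogen-bond donor in compound 4 leaves no visible mark on the read-out. No measurement at hand explains why these exchanges leave the read-out level.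

Still open, on these data alone, is whether an amine, a carboxylic acid or a longer alkyl chain on this carbon would give a step beyond the scatter, since the three groups compared so far carry no net charge and none of them is a chain. Also open is whether this flat response would hold on a different core, as every compound shown shares the same one.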